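Halogenated phenoxy ethers on a shared core: step to compound 4

The compounds below may be only part of what the source reports. "The series", "measured", "known", "first", "only" and "open" are said of these compounds alone.

Measured so far in a functional assay on MDA-MB-231 cells (Homo sapiens) for antiproliferative activity, read by MTT assay, with a stated time of 72 h; on this read-out lower numbers stand for stronger inhibition and higher numbers for weaker inhibition:
compound 1 `NC1=NC2(CCOCC2)N(OCCCOc2cccc(Cl)c2)C(N)=N1` gives 1020 nM
compound 2 `NC1=NC2(CCSCC2)N(OCCCOc2ccc(Cl)cc2)C(N)=N1` gives 350 nM
compound 3 `NC1=NC2(CCOCC2)N(OCCCOc2cccc(Br)c2)C(N)=N1` gives 400 nM

Compound 2 carries the lowest number of the three in this assay, but compound 3 sits within the scatter of it, so the two cannot be ordered; only compound 1 stands clearly apart with a higher number.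

The next compound, compound 4 `NC1=NC2(CCSCC2)N(OCCCOc2ccccc2Br)C(N)=N1`, keeps the core of compound 2 and differs from it in one place: 2-bromophenyl in place of 4-chlorophenyl on an oxygen on a saturated carbon.

Going by the values given here, one measured step bears on this change. Bromo in place of chloro on an aromatic carbon gave a 2.6-fold lower number from compound 1 to compound 3 (0.41 log units; beyond the scatter). Among the compounds with values here, that comparison, however, swaps the halogen at a fixed position, whereas compound 4 moves the halogen to another position on the ring as well as changing it; no measured pair covers that second part. The expectation for this assay is therefore a modest lower number at most, or none beyond the scatter, with the halogen swap as the only supported contribution.

Compound 4 is expected to give 260 nM, within 110 nM to 650 nM, which means an expected step of a 1.3-fold lower number from compound 2 to compound 4 (0.13 log units; within the scatter).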

Compound 4, half-maximal inhibitory concentration: 10 nM
Estimate against measurement, compound 4: 26-fold (1.41 log units) above; the measured number lies below the stated range.
By their numbers in this assay, from the lowest: compound 4; then compounds 2 and 3 (each within the scatter of the next); then compound 1.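

In this assay, going by these compounds alone, 2-bromophenyl in place of 4-chlorophenyl on an oxygen on a saturated carbon gives a 35-fold lower number from compound 2 to compound 4 (1.54 log units; beyond the scatter) and makes compound 4 the compound with the lowest number so far. Within the data shown here, this is well outside the size of the only earlier one-place step, a 2.6-fold lower number from compound 1 to compound 3 (0.41 log units; beyond the scatter) on the other core, and shows that the aromatic group at this place can shift the number far more than that halogen swap alone suggested. Among these compounds, the new step changes the halogen and its ring position together, and nothing measured so far accounts for its size.

On these data alone, how much of the step belongs to the bromine and how much to its ring position remains open; 2-chlorophenyl and 4-bromophenyl on the core of compound 2 would divide the two contributions. Also open, as far as these compounds go, are whether 2-bromophenyl keeps this effect on the core of compound 1, and whether a non-halogen group such as 2-methoxyphenyl or a longer chain to the phenoxy oxygen would hold a number of this order.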